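Dropping the Nitro Group from a Selenocyanate Carbamate

The compounds below may be only part of what the source reports. "The series", "measured", "known", "first", "only" and "open" are said of these compounds alone.

Compound 1, `CC(C)COC(=O)Nc1ccc([Se]C#N)cc1`: 31300 nM
Compound 2, `N#C[Se]c1ccc(NC(=O)OCc2ccc([N+](=O)[O-])cc2)cc1`: 47100 nM

Both numbers come from a functional assay on HT-29 cells (Homo sapiens) for cytotoxicity, read by MTT assay, with a stated time of 72 h; a lower number here means a stronger inhibitor of growth, a higher number a weaker inhibitor of growth. Compound 2 has the higher of the two numbers, and its nearest neighbour, compound 1, lies within the usual scatter of repeated measurements, so the two cannot be told apart on this evidence. Compound 3, `N#C[Se]c1ccc(NC(=O)OCc2ccccc2)cc1`, differs from compound 2 in one place only: hydrogen in place of nitro on an aromatic carbon. Among the measured compounds shown here, no measured pair in this small set shows what such a change does in this assay, so there is no step to lean on. Because compound 2 gives 47100 nM and compound 1 gives 31300 nM, both in the weak range, the expected step is a 1.2-fold lower number from compound 2 to compound 3 (0.07 log units; within the scatter), no larger than the scatter in either direction. Compound 3 is therefore expected to give 40000 nM, with a range from 15000 nM to 100000 nM.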

Compound 3, concentration for total growth inhibition: 41200 nM
For compound 3 the middle estimate is 1.0-fold (0.01 log units) below the measured one; the measured number falls inside the stated range.
By their numbers in this assay, from the lowest: compounds 1, 3 and 2 (each within the scatter of the next).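

In this assay the exchange of nitro for hydrogen on the aromatic carbon gives a 1.1-fold lower number from compound 2 to compound 3 (0.06 log units; within the scatter) and so shows that, at this position, the number does not measurably depend on the nitro group. The exchange at the other end of the carbamate, phenyl in place of isopropyl on a saturated chain carbon bound to an oxygen next to a carbonyl group, gives a 1.3-fold higher number from compound 1 to compound 3 (0.12 log units; within the scatter) and likewise leaves the two compounds indistinguishable. No measurement shown gives a reason for either result.

Going by these compounds, it remains open whether an amine or a carboxylic acid on this aromatic carbon, or a longer chain in place of the isopropyl end, would move the number beyond the scatter. All three compounds keep the selenocyanate group, so its contribution to growth inhibition cannot be read from them.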